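Amide side-chain swap on a chemokine receptor antagonist

The compounds below may be only part of what the source reports. "The series", "measured", "known", "first", "only" and "open" are said of these compounds alone.

Within the data shown here, compound 3 `COc1cccc2c1c(NS(=O)(=O)c1ccc(Cl)s1)nn2Cc1cccc(CNC(=O)C2COC2)c1` is one of three compounds measured in a functional assay on CHO cells for antagonist activity at C-C chemokine receptor type 4 (Homo sapiens), read by GTPgammaS binding (on this read-out lower numbers stand for stronger inhibition and higher numbers for weaker inhibition), where compound 3 gives 20 nM. Among the measured compounds shown here, compound 2 `CC(=O)NCc1cccc(Cn2nc(NS(=O)(=O)c3ccc(Cl)s3)c3c(C(C)O)cccc32)c1` gives 20 nM in this assay, and compound 1 `CC(=O)NCc1cccc(Cn2nc(NS(=O)(=O)c3ccc(Cl)s3)c3c(O)cccc32)c1` gives 12.6 nM; the step of a 1.6-fold higher number from compound 1 to compound 2 (0.20 log units; within the scatter) is the only one-place step measured, and it concerns the core, not the amide side chain. Compound 4 `CN[C@H](C)C(=O)NCc1cccc(Cn2nc(NS(=O)(=O)c3ccc(Cl)s3)c3c(OC)cccc32)c1` differs from compound 3 by 1-(methylamino)ethyl in place of oxetan-3-yl on a carbonyl carbon. For the measured compounds named here, no measured step touches that position, and all three measured values sit close together, so compound 4 is expected to show only no change at the digits printed from compound 3 to compound 4 (within the scatter) in this assay. Compound 4 is therefore estimated at 20 nM, with a range from 8 nM to 50 nM.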

Compound 4, half-maximal inhibitory concentration: 15.9 nM
The estimate for compound 4 lay 1.3-fold (0.10 log units) above the measured number, within the range that was stated.
By their numbers in this assay, from the lowest: compounds 1, 4, 2 and 3 (each within the scatter of the next).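

In this assay, among these compounds, the exchange on this carbonyl carbon gives a 1.3-fold lower number from compound 3 to compound 4 (0.10 log units; within the scatter) and is the first measured step at the amide side chain. At this position, open-chain 1-(methylamino)ethyl, with its hydrogen-bond donor and defined stereocentre, therefore reads the same within the scatter as the four-membered ring of oxetan-3-yl. Nothing available explains this result. Still open, going by these compounds, is how the opposite stereoisomer of 1-(methylamino)ethyl, a primary amine or a carboxylic acid would read on this carbonyl carbon. Also open, on these data alone, is whether a longer chain there would stay within the scatter.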